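A few compounds are considered here, and "the series" means these few. Any claim that something is new, unique, unknown or untested is made for them only; others in the source may bear on it.

Measured compounds in the series:

- compound 1, `COc1cc2nc(N3CCC4CCC(C3)N4Cc3ccccc3)nc(Nc3ccc(S(C)(=O)=O)cc3)c2cc1OC`: 23.4%
- compound 2, `COc1cc2nc(Nc3ccc(S(C)(=O)=O)cc3)nc(OC3CCN(C(=O)OC(C)(C)C)CC3)c2cc1OC`: 20.6%

Both numbers come from a functional assay on HEK293 cells for agonist activity at Glucose-dependent insulinotropic receptor (Homo sapiens), read by cAMP accumulation, with a stated time of 60 min; a higher number here means a larger maximal response, a lower number a smaller maximal response. For the measured compounds named here, compound 1 and compound 2 stand together: the gap between them lies within the scatter of repeated measurements, so neither can be placed above the other, and with only two numbers no trend in this assay can be drawn.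

Compound 3, `COc1cc2nc(N3CCC4CCC(C3)N4C(=O)OC(C)(C)C)nc(Nc3ccc(S(C)(=O)=O)cc3)c2cc1OC`, is not yet measured. It differs from compound 1 in one place, (tert-butoxycarbonyl in place of benzyl on an amine nitrogen in a ring). Going by the values given here, compound 2 already carries a tert-butoxycarbonyl on a ring nitrogen, though on a different ring, and its value sits with that of compound 1 within the scatter; no step between measured pairs differing in one place is available. On this basis the change from compound 1 to compound 3 is expected to bring no step beyond the scatter, with the expected step of a number 2.4 percentage points lower from compound 1 to compound 3 (within the scatter) in this assay. Compound 3 is therefore estimated at 21% in this assay, with a range of 9% to 34%.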

Compound 3, largest response reached (Emax), in percent of the reference or control that the assay uses: 32.7%
Compound 3: middle estimate off by 11.7 percentage points, on the low side; the range from low to high includes it.
By their numbers in this assay, from the lowest: compounds 2, 1 and 3 (each within the scatter of the next, the first and the last beyond it).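

For the compounds shown here, on the amine nitrogen of the five-membered non-aromatic ring, within a fused or bridged system of two rings, the one-place exchange of benzyl for tert-butoxycarbonyl gives in this assay a number 9.3 percentage points higher from compound 1 to compound 3 (within the scatter), the first reading of a single change. The exchange removes the six-membered aromatic ring of benzyl and brings in a carbonyl and hydrogen-bond acceptors, yet the maximal response stays within the scatter, so for this pair neither that aromatic ring nor a group without acceptors is required at this nitrogen for a response of this size. No measurement of any property of the two groups bears on this result, and its origin remains unassigned.

Still open, from the compounds shown here alone, is whether this nitrogen carrying only a hydrogen, or a small group such as methyl or acetyl, would keep the response within the same range or move it beyond the scatter. Also open, going by these compounds, is whether the same exchange, with benzyl on the ring nitrogen of compound 2 in place of tert-butoxycarbonyl, would give a comparable step on that different ring.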